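Swapping the aryl group on the pyrazole nitrogen: cytotoxicity outlook

The compounds below may be only part of what the source reports. "The series", "measured", "known", "first", "only" and "open" are said of these compounds alone.

Measured compounds:
- compound 1, `COc1ccc(-n2cc(CNCCN3CCN(C)CC3)c(-c3ccccc3C)n2)cc1`: > 20000 nM
- compound 2, `CCCN1CCC(CNCc2cn(-c3ccc([N+](=O)[O-])cc3)nc2-c2ccc(OC(F)(F)F)cc2)CC1`: 18000 nM
- compound 3, `Cc1ccccc1-c1nn(-c2ccc(F)cc2F)cc1CN1CCC(N2CCCCC2)CC1`: > 20000 nM

In an ADME assay on Huh-7 cells (Homo sapiens) for cytotoxicity (on this read-out higher numbers stand for lower toxicity in this test and lower numbers for higher toxicity in this test), compound 1 gives > 20000 nM, which is a limit of the assay and not a number. Compound 3 likewise gives > 20000 nM, also a limit. Compound 2 gives 18000 nM in this assay. So compound 1 stands at the top of the values shown, and the limit of > 20000 nM in this assay, at which 2 of the 3 values shown sit, describes where two of the three sit.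

Compound 4, `Cc1ccccc1-c1nn(-c2cccc(Cl)c2)cc1CNCCN1CCN(C)CC1`, differs from compound 1 by 3-chlorophenyl in place of 4-methoxyphenyl on an aromatic nitrogen. Within the data shown here, no measured pair shows the effect of such a change, so the step that the limit leaves unreadable from compound 1 to compound 4 is expected to be none beyond the scatter. Compound 4 is expected to give about 25000 nM, within 10000 nM to 60000 nM.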

Compound 4, half-maximal cytotoxic concentration: 16000 nM
Compound 4: the middle estimate sits 1.6-fold (0.19 log units) above what was measured; low and high end bracket the measured number.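

Among these compounds, at this position on the aromatic nitrogen, 3-chlorophenyl in place of 4-methoxyphenyl gives the first readable step in this assay: an at least 1.2-fold lower number from compound 1 to compound 4 (0.09 log units; that floor lies within the scatter). That step shows no change that can be told apart from the scatter, yet compound 4 gives 16000 nM, a real number and not a limit. Only a floor can be read, and the true size of the step stays unknown, because compound 1 sits at a limit: the limit of > 20000 nM in this assay, at which 2 of the 4 values shown sit.

The compounds shown leave open how an amine or a carboxylic acid in place of the chlorine would read here. They also leave open whether 3-chlorophenyl would act alike with the side chain of compound 3.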